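Ester and alkene variation in the tetrahydropyran series

A few compounds are considered here, and "the series" means these few. Any claim that something is new, unique, unknown or untested is made for them only; others in the source may bear on it.

Four compounds share a tetrahydropyranyl enoate framework. Compound 1 `O=C(/C=C/[C@H]1OCCC[C@H]1O)OCc1ccccc1` carries a benzyl ester and a free hydroxyl; compound 2 `CC(C)(C)[Si](C)(C)O[C@@H]1CCCO[C@@H]1/C=C\C(=O)OCc1ccccc1` carries the benzyl ester with the hydroxyl silylated; compound 3 `COC(=O)/C=C\[C@H]1OCCC[C@H]1O[Si](C)(C)C(C)(C)C` is its methyl ester; compound 4 `COC(=O)/C=C/[C@H]1OCCC[C@H]1O` pairs the methyl ester with the free hydroxyl and is not yet measured. How the core of compound 1 and the core of compound 2 differ is not broken down here.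

In a functional assay on A2780 cells (Homo sapiens) for antiproliferative activity, read by sulforhodamine B assay, with a stated time of 48 h (on this read-out higher numbers stand for weaker inhibition of growth and lower numbers for stronger inhibition of growth), compound 1 reports only a limit, > 100000 nM. Compound 2 gives 29000 nM in this assay, and compound 3 gives 7300 nM. The step of a 4.0-fold lower number from compound 2 to compound 3 (0.60 log units; beyond the scatter) arises from the change (hydrogen in place of phenyl on a saturated chain carbon bound to an oxygen next to a carbonyl group).

The same change is made from compound 1 to compound 4, namely (hydrogen in place of phenyl on a saturated chain carbon bound to an oxygen next to a carbonyl group), and its place matches that of the measured step word for word. From the compounds shown here alone, because compound 1 sits at the limit of > 100000 nM in this assay, at which 1 of the 3 values shown sits, the starting point for compound 4 is unknown in size, so the expected step of an at least 2.0-fold lower number from compound 1 to compound 4 (0.30 log units; that floor lies within the scatter) is estimated from the one measured occurrence, and compound 4 is expected to remain weak. Compound 4 is therefore estimated at 50000 nM in this assay, with a range expected from 12000 nM to 400000 nM, and a real chance that only a limit is returned for compound 4.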

Compound 4, concentration for 50% growth inhibition: > 100000 nM
Compound 4 was reported as a limit (the forecaster's own chance of this, stated with the estimate: 40%); middle value at least 2.0-fold (0.30 log units) away from the limit.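

Compound 1 and compound 4 both return only a limit in this assay, so the step from compound 1 to compound 4 cannot be read: the limit of > 100000 nM in this assay, at which 2 of the 4 values shown sit.

The compounds shown leave open whether hydrogen in place of phenyl changes growth inhibition at all in the free hydroxyl pair, compound 1 and compound 4, as it does in the silylated pair, compound 2 and compound 3.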